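The source may hold more compounds than are shown below. What is called first, only, known or untested is meant among the compounds shown, and "the series" means these compounds.

Of the compounds shown here, three built on one shared core have been measured in a functional assay on MGC-803 cells (Homo sapiens) for inhibition, read by MTT assay, with a stated time of 72 h; on this read-out higher numbers stand for weaker inhibition and lower numbers for stronger inhibition. Compound 1 `Cc1cc(N2CC[C@@H](C)[C@@H](N(C)c3ncnc4[nH]ccc34)C2)n2ncnc2n1` carries hydrogen on the aromatic carbon that the other two substitute, and in this assay compound 1 gives 4350 nM. Compound 2 `Cc1cc(N2CC[C@@H](C)[C@@H](N(C)c3ncnc4[nH]ccc34)C2)n2nc(SCc3nc4ccccc4[nH]3)nc2n1` bears ((1H-benzimidazol-2-yl)methyl)sulfanyl there, and compound 2 gives 21200 nM. Compound 3 `Cc1cc(N2CC[C@@H](C)[C@@H](N(C)c3ncnc4[nH]ccc34)C2)n2nc(SCC3CCCCC3)nc2n1` bears (cyclohexylmethyl)sulfanyl, and compound 3 gives 9170 nM. Compound 3 thus stands second highest of the three numbers, set apart by a 2.1-fold higher number from compound 1 to compound 3 (0.32 log units; beyond the scatter) and by a 2.3-fold lower number from compound 2 to compound 3 (0.36 log units; beyond the scatter).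

Compound 4 `CCCSc1nc2nc(C)cc(N3CC[C@@H](C)[C@@H](N(C)c4ncnc5[nH]ccc45)C3)n2n1` differs from compound 3 on the saturated chain carbon bound to a sulfur: ethyl in place of cyclohexyl on a saturated chain carbon bound to a sulfur. Going by the values given here, two measured steps bear on this place. The step of a 2.3-fold lower number from compound 2 to compound 3 (0.36 log units; beyond the scatter) shows that exchanging the group on that carbon shifts the number modestly, and the step of a 2.1-fold higher number from compound 1 to compound 3 (0.32 log units; beyond the scatter) shows that (cyclohexylmethyl)sulfanyl in place of hydrogen raised the number modestly. Propylsulfanyl lies between hydrogen and (cyclohexylmethyl)sulfanyl in size, so a modest downward step is expected, a 1.5-fold lower number from compound 3 to compound 4 (0.17 log units; within the scatter), moving toward the number of compound 1 without a clear basis to reach it. Compound 4 is therefore estimated at 6200 nM, within a range from 3000 nM to 13000 nM.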

Compound 4, half-maximal inhibitory concentration: 15500 nM
The estimate for compound 4 lay 2.5-fold (0.40 log units) below the measured number; the measured number lies above the stated range.
By their numbers in this assay, from the lowest: compound 1; then compounds 3, 4 and 2 (each within the scatter of the next, the first and the last beyond it).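

In this assay, ethyl in place of cyclohexyl on the saturated chain carbon bound to a sulfur gives a 1.7-fold higher number from compound 3 to compound 4 (0.23 log units; within the scatter), and ethyl in place of 1H-benzimidazol-2-yl at the same carbon gives a 1.4-fold lower number from compound 2 to compound 4 (0.14 log units; within the scatter), so neither exchange moves the number beyond the usual scatter. Compound 4 thus cannot be told apart from either ring-bearing compound, even though those two stand apart from each other. The remaining step, a 3.6-fold higher number from compound 1 to compound 4 (0.55 log units; beyond the scatter), shows that propylsulfanyl, which carries no ring, also takes the number up from that of the hydrogen compound, so among the compounds shown a ring on the chain is not needed for this rise and no sulfanyl compound goes against it. No information is available here on what lies behind these numbers.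

As far as these compounds go, whether an oxygen or an amine nitrogen in place of the sulfur would read like compound 1 or like the sulfanyl compounds remains open. So does how a methyl group, a longer chain or a carboxylic acid at the end of the chain would read.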